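Replacing the 4-(methoxymethyl)phenyl group of compound 2

The source may report more compounds than this note shows. Statements on the series, on what has been measured and on what is new or still open speak of the compounds shown alone.

For the measured compounds named here, in a functional assay on KBVIN cells (Homo sapiens) for antiproliferative activity, read by sulforhodamine B assay, with a stated time of 3 days (on this read-out lower numbers stand for an effect already at smaller amounts and higher numbers for an effect only at larger amounts of compound), compound 2 `CCC1=C(O)c2c(oc(-c3ccc(COC)cc3)cc2=O)C(CC)(CC)C1=O` gives 3.4 uM, the lower of the two numbers so far, while compound 1 `CCC1=C(O)c2c(oc(-c3ccc(O)cc3)cc2=O)C(CC)(CC)C1=O` gives 20.6 uM. Compound 3 `CCC1=C(O)c2c(oc(-c3cccc(C)c3)cc2=O)C(CC)(CC)C1=O` carries 3-methylphenyl in place of 4-(methoxymethyl)phenyl on an aromatic carbon. Going by the values given here, the only measured guide is a modest step, a 6.1-fold lower number from compound 1 to compound 2 (0.78 log units; beyond the scatter), with methoxymethyl in place of hydroxy on an aromatic carbon. It shows that the number can move with a change on this group, but no methyl group has been measured yet. The expected change is small, a 1.7-fold lower number from compound 2 to compound 3 (0.23 log units; within the scatter), and a shift beyond the scatter is not expected. Compound 3 is estimated at 2 uM, with an expected range from 0.4 uM to 9 uM.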

Compound 3, concentration for half-maximal effect: 3.69 uM
Beside the measured number, compound 3's estimate is 1.8-fold (0.27 log units) below it, within the range that was stated.
By their numbers in this assay, from the lowest: compounds 2 and 3 (each within the scatter of the next); then compound 1.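

In this assay, 3-methylphenyl in place of 4-(methoxymethyl)phenyl gives a 1.1-fold higher number from compound 2 to compound 3 (0.04 log units; within the scatter), so this position accepts a group without oxygen and with fewer heavy atoms, with no change that can be told from scatter. The step of a 5.6-fold lower number from compound 1 to compound 3 (0.75 log units; beyond the scatter) shows that the gap from compound 1 is not tied to the methoxymethyl group. No measurement here explains why these two different groups read alike. From the compounds shown here alone, whether a plain phenyl group, or a phenyl ring carrying an amine or a carboxylic acid, would read like compound 3 or like compound 1 stays open.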